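A few compounds are considered here, and "the series" means these few. Any claim that something is new, unique, unknown or untested is made for them only; others in the source may bear on it.

Measured compounds in an assay on CHO-K1 cells for displacement of a labelled ligand from prostaglandin E2 receptor EP1 subtype (Homo sapiens); a higher number here means a weaker inhibitor, a lower number a stronger inhibitor:
- compound 1 `Cc1cc(C(=O)NCc2ccccn2)nn1Cc1cc(Cl)ccc1OCc1ccccc1`, which gives 25.1 nM
- compound 2 `Cc1cc(C(=O)NN2CCCCC2)nn1Cc1cc(Cl)ccc1OCC(C)C`, which gives 200 nM
- compound 3 `Cc1cc(NC(=O)CC(C)(C)C)nn1Cc1cc(Cl)ccc1OCc1ccccc1`, which gives 10 nM

Compound 2 stands highest of the three numbers: compound 1 and compound 3 both sit at lower values, in each case by a gap beyond the scatter, so compound 2 is the weakest inhibitor here. Compound 4 `Cc1cc(NC(=O)OC(C)(C)C)nn1Cc1cc(Cl)ccc1OCC(C)C` keeps the core and the isobutoxy-bearing side of compound 2 and differs in one place: (tert-butoxycarbonyl)amino in place of (piperidin-1-yl)carbamoyl on an aromatic carbon. In words, the (piperidin-1-yl)carbamoyl group leaves and a (tert-butoxycarbonyl)amino group enters on the same aromatic carbon.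

Within the data shown here, one measured step bears on this. Going a 2.5-fold lower number from compound 1 to compound 3 (0.40 log units; beyond the scatter), a carbamoyl group was replaced by an acylamino group on the same ring carbon, so the direction of the amide was turned around while a branched alkyl group was kept. The change from compound 2 to compound 4 likewise turns the amide around and keeps a branched alkyl, though here an oxygen now sits between carbonyl and tert-butyl, and the rest of the molecule differs from compound 1. Among the measured compounds shown here, a modest lowering of the number, of the size seen from compound 1 to compound 3, is therefore the expectation, with wide uncertainty because only one step informs it.

Compound 4 is thus expected to give about 80 nM in this assay, most likely between 25 nM and 250 nM, an expected step of a 2.5-fold lower number from compound 2 to compound 4 (0.40 log units; beyond the scatter).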

Compound 4, half-maximal inhibitory concentration: 31.6 nM
Estimate against measurement, compound 4: 2.5-fold (0.40 log units) above; low and high end bracket the measured number.
By their numbers in this assay, from the lowest: compound 3; then compounds 1 and 4 (each within the scatter of the next); then compound 2.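

In this assay the exchange on this aromatic carbon gives a 6.3-fold lower number from compound 2 to compound 4 (0.80 log units; beyond the scatter), so the lowering seen in a 2.5-fold lower number from compound 1 to compound 3 (0.40 log units; beyond the scatter), where a carbamoyl group also gave way to an acylamino group, appears again with the isobutoxy side in place of the benzyloxy one; these are the only two such pairs shown, and neither goes against this direction. The (piperidin-1-yl)carbamoyl group and its ring are not required for a number this low, and the (tert-butoxycarbonyl)amino group that enters has no ring but the same counts of hydrogen-bond donors and acceptors, so those counts do not distinguish the two compounds. Nothing measured here explains why the number falls at this position.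

It remains open how much the isobutoxy and benzyloxy sides contribute on their own, as no pair shown differs only there, and whether the oxygen in the (tert-butoxycarbonyl)amino group matters, as compound 3 and compound 4 differ in more than one place. Also open, as far as these compounds go, is how a carboxylic acid, a urea or a simple primary amine would fare on this aromatic carbon.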